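Exposure notes: dimethylamino in place of methoxy on the shared core

The source may report more compounds than this note shows. Statements on the series, on what has been measured and on what is new or still open speak of the compounds shown alone.

Compound 1 `CCCS(=O)(=O)Nc1ccc(Cl)c(C(=O)Nc2cnc3[nH]nc(OC)c3c2)c1F` stands higher of the two measured compounds: in an ADME assay on the whole organism (plasma, strain CD-1) for pharmacokinetics, with Mus musculus as the target, at a dose of 30 mg/kg by the oral route (on this read-out higher numbers stand for higher exposure at the dose given and lower numbers for lower exposure), compound 1 gives 1080000 ng.h/mL. Compound 2 `CCCS(=O)(=O)Nc1ccc(F)c(C(=O)Nc2cnc3[nH]nc(OC)c3c2)c1F` gives 190000 ng.h/mL in this assay, the lowest of the two numbers, set apart by the one step shown, a 5.7-fold lower number from compound 1 to compound 2 (0.75 log units; beyond the scatter). Compound 3 `CCCS(=O)(=O)Nc1ccc(F)c(C(=O)Nc2cnc3[nH]nc(N(C)C)c3c2)c1F` differs from compound 2 in a single place: dimethylamino in place of methoxy on an aromatic carbon. No measured step bears directly on this change; the only step shown concerns a halogen elsewhere on the shared core and says only that a single change on this core can move this assay beyond the scatter. With nothing to set the direction, compound 3 is expected to stay close to compound 2, with an expected step of a 1.3-fold lower number from compound 2 to compound 3 (0.10 log units; within the scatter) that lies within the scatter. The estimate for compound 3 in this assay is 150000 ng.h/mL, with a range from 35000 ng.h/mL to 600000 ng.h/mL.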

Compound 3, area under the concentration-time curve: 1090 ng.h/mL
The estimate for compound 3 lay 140-fold (2.14 log units) above the measured number, outside the stated range (below it).
By their numbers in this assay, from the lowest: compound 3; then compound 2; then compound 1.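

The change from methoxy to dimethylamino, on an aromatic carbon of the five-membered aromatic ring, gives a larger move in this assay than the halogen change: a 170-fold lower number from compound 2 to compound 3 (2.24 log units; beyond the scatter), against a 5.7-fold lower number from compound 1 to compound 2 (0.75 log units; beyond the scatter). This position therefore matters at least as much for exposure at this dose as the halogen site, even though the two groups differ little in size and are counted alike for hydrogen-bond donors and acceptors. The data shown offer no explanation for this step.

Still open, going by these compounds, is whether the fall belongs to dimethylamino alone or extends to other amines at this position, such as a primary amine, methylamino or morpholine. Also open, on these data alone, are whether the same change on the chloro compound, compound 1, gives a similar step, and whether a longer alkoxy group such as ethoxy stays close to methoxy.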